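The source may report more compounds than this note shows. Statements on the series, on what has been measured and on what is new or still open speak of the compounds shown alone.

Measured so far in an assay on HEK293 cells for activation of Kir3.1/Kir3.2 (Homo sapiens), read by thallium flux; on this read-out lower numbers stand for smaller maximal responses and higher numbers for larger maximal responses:
Compound 1 `Cc1cc(NC(=O)Cn2nnc(-c3ccccc3)n2)n(C2CCCCC2)n1` gives 92%.
Compound 2 `Cc1cc(NC(=O)Cn2nnc(-c3ccccc3)n2)n(C2CCC(C)(C)CC2)n1` gives only a limit, > 19%.
Compound 3 `CCC(C)n1nc(C)cc1NC(=O)Cn1nnc(-c2ccccc2)n1` gives only a limit, > 69%.

Compound 3 therefore stands at a limit of this assay and not at a number, and one further value in the set is likewise a limit. Compound 4 `Cc1cc(NC(=O)Cn2nnc(-c3ccccc3)n2)n(C2CC2)n1` differs from compound 3 in one place: cyclopropyl in place of sec-butyl on an aromatic nitrogen. All three measured steps change the group on the same aromatic nitrogen, namely a step that the limit leaves unreadable from compound 1 to compound 2, a step that the limit leaves unreadable from compound 1 to compound 3 and a step that the two limits leave unreadable from compound 2 to compound 3, and none of them can be sized because of the limit of > 19% in this assay, at which 1 of the 3 values shown sits, and (the limit of > 69% in this assay, at which 1 of the 3 values shown sits). No readable step at this position is thus available. Among the compounds with values here, compound 1 gives a large maximal response, and compound 3 sits at its limit, so a large maximal response is expected for compound 4 as well, with an expected step that the limit leaves unreadable from compound 3 to compound 4 that no measured step can confirm. Compound 4 is expected to reach 80%, within a range from 40% to 100%.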

Compound 4, largest response reached (Emax), in percent of the reference or control that the assay uses: > 78%
Compound 4 ended at the assay's limit; the forecaster's own chance of this, stated with the estimate: 30%; the middle value does not contradict the limit.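

In this assay compound 4 gives > 78%, which is a limit and not a number. The steps to compound 4 from compound 1, compound 2 and compound 3 cannot be read. The compounds shown leave open how far the maximal response changes with the group on the aromatic nitrogen.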